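The source may report more compounds than this note shows. Statements on the series, on what has been measured and on what is new or still open speak of the compounds shown alone.

Compound 1 `CCC(C)(C)Cc1c[nH]c(CCc2ccc(-c3ccc(F)cn3)cc2)n1` gives 105 nM in a functional assay on HEK293 cells for agonist activity at Bombesin receptor subtype-3 (Mus musculus), read by luminescence and calcium flux, with a stated time of 10 min; on this read-out higher numbers stand for an effect only at larger amounts of compound and lower numbers for an effect already at smaller amounts.
Compound 2 `CCC(C)(C)Cc1c[nH]c(CCc2ccc(-c3cccc(N)n3)cc2)n1` gives 119 nM.
Compound 3 `CCC(C)(C)Cc1c[nH]c(CCc2ccc(-c3csnn3)cc2)n1` gives 109 nM.

Compound 3 stands second highest of these three numbers, but its gaps to compound 1 and compound 2 both lie within the scatter, so the three compounds cannot be told apart. Compound 4 `CCC(C)(C)Cc1c[nH]c(CCc2ccc(-c3cnsc3)cc2)n1` differs from compound 3 in one place: 1,2-thiazol-4-yl in place of 1,2,3-thiadiazol-4-yl on an aromatic carbon. Among the compounds with values here, three steps bear on this, each an exchange of the ring group at the same position: a 1.0-fold higher number from compound 1 to compound 3 (0.02 log units; within the scatter), a 1.1-fold lower number from compound 2 to compound 3 (0.04 log units; within the scatter) and a 1.1-fold higher number from compound 1 to compound 2 (0.05 log units; within the scatter), all within the scatter. The exchange in compound 4 is therefore expected to give no step beyond the scatter in this assay, as a 1.0-fold higher number from compound 3 to compound 4 (0.00 log units; within the scatter). Compound 4 is estimated at 110 nM, with a range from 55 nM to 220 nM.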

Compound 4, half-maximal effective concentration: 119 nM
Compound 4: the middle estimate sits 1.1-fold (0.03 log units) below what was measured, within the range that was stated.
By their numbers in this assay, from the lowest: compounds 1, 3, 2 and 4 (each within the scatter of the next).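

Going from the five-membered aromatic ring with 3 hetero atoms to the one with 2 hetero atoms, on the aromatic carbon para to a large group, gives a 1.1-fold higher number from compound 3 to compound 4 (0.04 log units; within the scatter) in this assay. The same holds against the six-membered rings, with no change at the digits printed from compound 2 to compound 4 (within the scatter) and a 1.1-fold higher number from compound 1 to compound 4 (0.05 log units; within the scatter) as the steps. This position therefore accepts a fourth aromatic ring group, five-membered or six-membered, with no step beyond the scatter among these compounds. No evidence here accounts for this flat result. On these data alone, whether a carboxylic acid or a saturated ring such as morpholine would fit here equally well stays open.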